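Working notes: from compound 1 to compound 4

A few compounds are considered here, and "the series" means these few. Any claim that something is new, unique, unknown or untested is made for them only; others in the source may bear on it.

Measured so far in a functional assay on the whole organism with Mus musculus as the target (on this read-out higher numbers stand for an effect only at larger amounts of compound and lower numbers for an effect already at smaller amounts), are these compounds
- compound 1 `O=C(/C=C1\CCc2ccccc21)NC1CC1` at 150 mg/kg
- compound 2 `NC(=O)/C=C1\CCc2ccccc21` at 108 mg/kg
- compound 3 `O=C(/C=C1\CCc2ccc(F)cc21)NC1CC1` at 66 mg/kg

In this assay compound 1 stands level with compound 2 within the scatter and above compound 3 on the numbers. The unmeasured compound 4 `O=C(/C=C1\CCc2c(Cl)cccc21)NC1CC1` follows from compound 1 by one change chloro in place of hydrogen on an aromatic carbon with chloro in place of hydrogen on an aromatic carbon, ortho to a fused ring and meta to a fused ring.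

For the measured compounds named here, the closest precedent is a 2.3-fold lower number from compound 1 to compound 3 (0.36 log units; beyond the scatter) with fluoro in place of hydrogen on an aromatic carbon. The other measured step, a 1.4-fold lower number from compound 1 to compound 2 (0.14 log units; within the scatter) on an amide-type nitrogen, bears little on this change. Going by the values given here, no measured compound carries chloro, so the precedent is thin. A small move toward a lower number is expected, possibly not clearing the scatter, and a 1.6-fold lower number from compound 1 to compound 4 (0.20 log units; within the scatter) is the estimated step.

Compound 4 is expected at 95 mg/kg within the range 45 mg/kg to 200 mg/kg as estimated.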

Compound 4, dose for half-maximal effect: 58 mg/kg
Beside the measured number, compound 4's estimate is 1.6-fold (0.21 log units) above it; the measured number falls inside the stated range.
By their numbers in this assay, from the lowest: compounds 4, 3, 2 and 1 (each within the scatter of the next, the first and the last beyond it).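

In this assay chloro in place of hydrogen, on the aromatic carbon ortho to a fused ring and meta to a fused ring, gives a 2.6-fold lower number from compound 1 to compound 4 (0.41 log units; beyond the scatter) and so shows that this position takes a chlorine atom with a modest move to a lower number. Before this, the only aromatic change on record was fluoro in place of hydrogen, with a 2.3-fold lower number from compound 1 to compound 3 (0.36 log units; beyond the scatter) at a different carbon; two aromatic substitutions on compound 1 now both lower the number beyond the scatter. No available evidence bears on why the number moves at this position.

Open, as far as these compounds go, is whether the position or the group drives the step, which fluoro, methyl or an amine on this same carbon would separate. Also open, from the compounds shown here alone, is whether chloro at this position has a similar effect on compound 2, which lacks the cyclopropyl group.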